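Amide to Urea: What Compound 4 May Show

The compounds below may be only part of what the source reports. "The series", "measured", "known", "first", "only" and "open" are said of these compounds alone.

Of the compounds shown here, three sharing one core have been measured in a functional assay on NCI-H522 cells (Homo sapiens) for inhibition, read by sulforhodamine B assay, with a stated time of 48 h; on this read-out higher numbers stand for weaker inhibition of growth and lower numbers for stronger inhibition of growth. Compound 1 `COc1cc(-c2nn(-c3cccc(NC(=O)c4cccc(C(F)(F)F)c4)c3)cc2-c2ccncc2)ccc1Cl` gives 3850 nM, compound 2 `COc1cc(-c2nn(-c3cccc(NC(=O)Nc4ccc(Cl)c(Cl)c4)c3)cc2-c2ccncc2)ccc1Cl` gives 3100 nM, and compound 3 `COc1cc(-c2nn(-c3cccc(NC(=O)c4ccc(Cl)c(C(F)(F)F)c4)c3)cc2-c2ccncc2)ccc1Cl` gives 13400 nM, the highest number of the three; its nearest neighbour is compound 1, with the step of a 3.5-fold higher number from compound 1 to compound 3 (0.54 log units; beyond the scatter), and its furthest is compound 2, with the step of a 4.3-fold higher number from compound 2 to compound 3 (0.64 log units; beyond the scatter). Compound 4 `COc1cc(-c2nn(-c3cccc(NC(=O)Nc4ccc(Cl)c(C(F)(F)F)c4)c3)cc2-c2ccncc2)ccc1Cl` has not yet been measured. It differs from compound 3 in one place: (4-chloro-3-(trifluoromethyl)phenyl)amino in place of 4-chloro-3-(trifluoromethyl)phenyl on a carbonyl carbon. Within the data shown here, the step that bears most directly on this change is the one from compound 1 to compound 2, which likewise exchanges a group on a carbonyl carbon for an amino-linked one, though with a different substitution pattern on the entering ring, and gave a 1.2-fold lower number from compound 1 to compound 2 (0.09 log units; within the scatter). On that basis the change is expected to move the number little in this assay, and compound 4 is expected to give 11000 nM, within 4000 nM to 30000 nM. The step from compound 3 to compound 4 is therefore estimated as a 1.2-fold lower number from compound 3 to compound 4 (0.09 log units; within the scatter).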

Compound 4, concentration for total growth inhibition: 6060 nM
For compound 4 the middle estimate is 1.8-fold (0.26 log units) above the measured one; low and high end bracket the measured number.
By their numbers in this assay, from the lowest: compounds 2, 1 and 4 (each within the scatter of the next); then compound 3.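

In this assay the amino link on the carbonyl carbon gave a 2.2-fold lower number from compound 3 to compound 4 (0.34 log units; beyond the scatter), so with 4-chloro-3-(trifluoromethyl)phenyl as the ring this change moved the number beyond the scatter, which the earlier step of a 1.2-fold lower number from compound 1 to compound 2 (0.09 log units; within the scatter) had not shown. Compound 4 also now stands within the scatter of both neighbours, with a 2.0-fold higher number from compound 2 to compound 4 (0.29 log units; within the scatter) for trifluoromethyl in place of chloro on an aromatic carbon and a 1.6-fold higher number from compound 1 to compound 4 (0.20 log units; within the scatter) for the exchange on the carbonyl carbon. No evidence is at hand that bears on this result.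

The compounds shown leave open whether the shift from the amino link holds for other rings on the carbonyl carbon. They also leave open how a methylene or an ether oxygen would read there in place of the amino nitrogen.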